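A few compounds are considered here, and "the series" means these few. Any claim that something is new, unique, unknown or untested is made for them only; others in the source may bear on it.

Measured in an in vitro ADME assay on microsomes from liver (Homo sapiens) for metabolic stability, read by HPLC; a lower number here means slower removal, a higher number faster removal of the compound:
- compound 1 `CC1(C)CO[C@H]1CN([C@H](CCC(F)(F)F)C(N)=O)S(=O)(=O)c1ccc(Cl)cc1`: 262 mL/min/kg
- compound 2 `NC(=O)[C@@H](CCC(F)(F)F)N(C[C@@H]1COCCO1)S(=O)(=O)c1ccc(Cl)cc1`: 117 mL/min/kg
- compound 3 `NC(=O)[C@@H](CCC(F)(F)F)N(C[C@H]1CCOC1)S(=O)(=O)c1ccc(Cl)cc1`: 83.4 mL/min/kg

Compound 3 stands level with compound 2, as a 1.4-fold lower number from compound 2 to compound 3 (0.15 log units; within the scatter) shows, and clearly apart from compound 1, as a 3.1-fold lower number from compound 1 to compound 3 (0.50 log units; beyond the scatter) shows. Compound 4 `NC(=O)[C@@H](CCC(F)(F)F)N(C[C@H]1CCCO1)S(=O)(=O)c1ccc(Cl)cc1` carries oxolan-2-yl in place of oxolan-3-yl on a saturated chain carbon bound to a sulfonamide nitrogen. Among the compounds with values here, no measured step covers this swap alone. The nearest evidence is the ring exchange a 1.4-fold lower number from compound 2 to compound 3 (0.15 log units; within the scatter), while the larger 2.2-fold lower number from compound 1 to compound 2 (0.35 log units; beyond the scatter) involves the 3,3-dimethyloxetan-2-yl group, which plays no part here. No step beyond the scatter is therefore expected in this assay, and the estimated move is a 1.2-fold higher number from compound 3 to compound 4 (0.08 log units; within the scatter). For compound 4 the expected value is 100 mL/min/kg, with an estimated range of 50 mL/min/kg to 200 mL/min/kg.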

Compound 4, clearance: 231 mL/min/kg
Estimate against measurement, compound 4: 2.3-fold (0.36 log units) below; the measured number lies above the stated range.
By their numbers in this assay, from the lowest: compounds 3, 2, 4 and 1 (each within the scatter of the next, the first and the last beyond it).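

At this place, on a saturated chain carbon bound to a sulfonamide nitrogen, exchanging oxolan-3-yl for oxolan-2-yl, with the same atoms joined differently, separates two compounds in this assay: a 2.8-fold higher number from compound 3 to compound 4 (0.44 log units; beyond the scatter). The oxolan-2-yl compound shows no separation from the 3,3-dimethyloxetan-2-yl or 1,4-dioxan-2-yl compounds: a 1.1-fold lower number from compound 1 to compound 4 (0.05 log units; within the scatter), and a 2.0-fold higher number from compound 2 to compound 4 (0.30 log units; within the scatter). No measured evidence bears on the reason for this difference. Open, as far as these compounds go, is whether an amine or a plain carbon ring at this place would read like oxolan-3-yl or like oxolan-2-yl.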